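Methyl on the aryl of compound 1: expected toxicity

The source may hold more compounds than are shown below. What is called first, only, known or untested is meant among the compounds shown, and "the series" means these compounds.

Measured so far in an ADME assay on HEK-293T cells (Homo sapiens) for antiproliferative activity, read by MTT assay, with a stated time of 48 h, in the presence of a further agent that is not named here; on this read-out lower numbers stand for higher toxicity in this test and higher numbers for lower toxicity in this test:
compound 1, `O=C(NOCc1ccccc1)c1cn(-c2ccccc2)nc1-c1ccccc1`, gives 122000 nM
compound 2, `O=C(NOCc1ccccc1F)c1cn(-c2ccccc2)nc1-c1ccccc1`, gives 75700 nM
compound 3, `O=C(NOCc1ccc(Cl)cc1Cl)c1cn(-c2ccccc2)nc1-c1ccccc1`, gives 40200 nM

Compound 1 gives the highest of the three numbers in this assay. Its gap to compound 2 lies within the scatter (a 1.6-fold lower number from compound 1 to compound 2 (0.21 log units; within the scatter)), whereas the step to compound 3 is beyond it (a 3.0-fold lower number from compound 1 to compound 3 (0.48 log units; beyond the scatter)), a modest lowering. The remaining step, a 1.9-fold lower number from compound 2 to compound 3 (0.27 log units; within the scatter), is again within the scatter.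

Compound 4, `Cc1ccc(-c2nn(-c3ccccc3)cc2C(=O)NOCc2ccccc2)cc1`, differs from compound 1 by methyl in place of hydrogen on an aromatic carbon; cut one bond further out, the change reads phenyl to 4-methylphenyl, on an aromatic carbon of a six-membered aromatic ring of carbon only, para to a large group. No measured step touches this ring: all three shown steps alter the benzyl group on the oxygen side of the shared core. The only other single-atom replacement of a hydrogen on an aromatic carbon, from compound 1 to compound 2, stayed within the scatter. A step of this kind in this assay is therefore not expected beyond the scatter, with a slight lean toward a lower number, as the shown steps all run in that direction.

For compound 4 the expected value is 95000 nM, within 45000 nM to 200000 nM, which means an expected step of a 1.3-fold lower number from compound 1 to compound 4 (0.11 log units; within the scatter).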

Compound 4, half-maximal cytotoxic concentration: 40800 nM
Compound 4: middle estimate off by 2.3-fold (0.37 log units), on the high side, outside the stated range (below it).
By their numbers in this assay, from the lowest: compounds 3, 4, 2 and 1 (each within the scatter of the next, the first and the last beyond it).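

Replacing phenyl with 4-methylphenyl gives a 3.0-fold lower number from compound 1 to compound 4 (0.48 log units; beyond the scatter), the only shown step at this ring, so in this assay the number responds to a change here as well as to changes in the benzyl group on the oxygen side. One added carbon is enough for a modest step toward higher toxicity in this test, matching the direction of the dichloro change, a 3.0-fold lower number from compound 1 to compound 3 (0.48 log units; beyond the scatter), whereas the single fluoro replacement on the benzyl group, a 1.6-fold lower number from compound 1 to compound 2 (0.21 log units; within the scatter), remains within the scatter. Nothing available accounts for the response at this position.

From the compounds shown here alone, whether this step is particular to methyl remains open: a chloro, a methoxy, an ethyl or a carboxylic acid on the same aromatic carbon would show whether the number follows the entering group or any replacement of hydrogen there. Also open, going by these compounds, is whether 4-methylphenyl and the 2,4-dichlorophenyl group on the oxygen side would lower the number further when combined, and whether methyl on the other phenyl of the shared core would give a comparable step.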